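A few compounds are considered here, and "the series" means these few. Any claim that something is new, unique, unknown or untested is made for them only; others in the source may bear on it.

Compound 2 `O=C(COc1ccc2cc(/C=C3/SC(=O)NC3=O)ccc2c1)Nc1ccc(Br)c(Br)c1` carries a 3,4-dibromophenyl on the amide nitrogen of a shared core. In an assay on isolated protein for inhibition of histone deacetylase 8 (Homo sapiens), with a stated time of 1 h (a higher number here means a weaker inhibitor, a lower number a stronger inhibitor), compound 2 gives only a limit, > 50000 nM, which is not a number. That puts it at the limit of > 50000 nM in this assay, at which 1 of the 2 values shown sits, the weakest position the numbers shown can express. Its closest measured relative, compound 1 `Cc1cccc2sc(NC(=O)COc3ccc4cc(/C=C5/SC(=O)NC5=O)ccc4c3)nc12`, gives 5800 nM in this assay, and the change between them, an at least 8.6-fold higher number from compound 1 to compound 2 (0.93 log units; beyond the scatter), shows that swapping the group on the amide nitrogen can move the number markedly.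

Compound 3 `O=C(COc1ccc2cc(/C=C3/SC(=O)NC3=O)ccc2c1)Nc1ccc([N+](=O)[O-])cc1` differs from compound 2 by 4-nitrophenyl in place of 3,4-dibromophenyl on an amide-type nitrogen. Among the measured compounds shown here, no measured pair shares this particular exchange, so the single measured step offers only a sense of scale, not a direction. Starting from a limit, compound 3 is expected to show an at least 1.6-fold lower number from compound 2 to compound 3 (0.22 log units; that floor lies within the scatter), most likely a slight improvement that may or may not yield a number. The estimate for compound 3 is therefore 30000 nM, within a range from 5000 nM to 100000 nM.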

Compound 3, half-maximal inhibitory concentration: 4000 nM
For compound 3 the middle estimate is 7.5-fold (0.88 log units) above the measured one; measured number below the stated range.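

In this assay, putting 4-nitrophenyl in place of 3,4-dibromophenyl on the amide-type nitrogen gives an at least 12-fold lower number from compound 2 to compound 3 (1.09 log units; beyond the scatter), so a phenyl ring at this position does not in itself rule out a measurable number. The data also give a 1.5-fold lower number from compound 1 to compound 3 (0.16 log units; within the scatter), so 4-nitrophenyl and 4-methyl-1,3-benzothiazol-2-yl, though quite different groups, cannot be told apart here. Compound 2 gives a limit and not a number, so its steps are floors rather than exact sizes: the limit of > 50000 nM in this assay, at which 1 of the 3 values shown sits.

With only three groups shown, it remains open whether the number depends on which substituents the phenyl ring carries or on how many it carries. A phenyl ring with no substituent, one with a single bromine, or one with an amine in place of the nitro group would help separate these possibilities.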